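From Compound 1 to Compound 3: One Ring Exchanged

This account rests on a few compounds, and the source may have more. Where it says the series, first, only, none or still open, it means among the compounds named here.

Compound 1 `O=C(/C(=C\c1ccc(Br)cc1)SCc1ccc(Cl)cc1)c1ccc(Br)cc1`: 1000 nM
Compound 2 `COc1ccc(S/C(=C/c2ccc(Br)cc2)C(=O)c2ccc(Br)cc2)cc1`: 20000 nM

Of the compounds shown here, two have been measured in a functional assay on DU-145 cells (Homo sapiens) for inhibition, read by trypan blue exclusion, with a stated time of 96 h; a higher number here means a weaker inhibitor of growth, a lower number a stronger inhibitor of growth. Compound 1 gives 1000 nM and stands lowest of the two numbers, with compound 2 nearest at 20000 nM. Within the data shown here, the single measured step, a 20-fold higher number from compound 1 to compound 2 (1.30 log units; beyond the scatter), comes from 4-methoxyphenyl in place of 4-chlorobenzyl on a sulfur. Compound 3 `Cc1ccsc1/C=C(/SCc1ccc(Cl)cc1)C(=O)c1ccc(Br)cc1` differs from compound 1 at another place: 3-methylthiophen-2-yl in place of 4-bromophenyl on a double-bonded chain carbon bound to a double-bonded chain carbon. Among the measured compounds shown here, no measured step touches the group on the double-bonded chain carbon, so the step from compound 1 to compound 2 gives no direct guide to how this assay responds there; what is known is only that a change elsewhere on the core of compound 1 moved the number a great deal. Compound 3 is therefore expected to stay near compound 1, with an estimated step of a 1.5-fold higher number from compound 1 to compound 3 (0.18 log units; within the scatter), likely within the scatter but carrying wide uncertainty. The estimate for compound 3 is 1500 nM, with a range from 400 nM to 6000 nM.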

Compound 3, concentration for 50% growth inhibition: 25000 nM
Estimate against measurement, compound 3: 17-fold (1.22 log units) below; measured number outside the range, above it.
By their numbers in this assay, from the lowest: compound 1; then compounds 2 and 3 (each within the scatter of the next).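

The step of a 25-fold higher number from compound 1 to compound 3 (1.40 log units; beyond the scatter) in this assay shows that the group on a double-bonded chain carbon bound to a double-bonded chain carbon is not a silent place: 3-methylthiophen-2-yl does not stand in for 4-bromophenyl here. With the earlier step of a 20-fold higher number from compound 1 to compound 2 (1.30 log units; beyond the scatter) at the sulfur, both single changes shown on the core of compound 1 now raise the number beyond the scatter, and compound 1 remains the lowest of the three. Nothing at hand bears on why this exchange has so large an effect.

The exchange swaps a six-membered ring of carbon only for a five-membered ring with a hetero atom and also removes the bromine, so the compounds shown do not separate these parts. On these data alone, how a plain phenyl, a pyridine ring, or a thiophen-2-yl without the methyl would read at this place remains open.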